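A Nitrile Gives Way to Hydrogen

The source may hold more compounds than are shown below. What is called first, only, known or untested is meant among the compounds shown, and "the series" means these compounds.

In an ADME assay on liver for metabolic stability, with Liver microsome (Rattus norvegicus) as the target, using microsomes (on this read-out higher numbers stand for a longer-lived compound and lower numbers for a shorter-lived compound), compound 1 `Cc1nc(-c2cc3cc(OC(C)C)cc(C#N)c3[nH]2)sc1C(=O)O` gives 2.17 h, and compound 2 `Cc1nc(-c2cc3cc(Oc4ccccc4)cc(C#N)c3[nH]2)sc1C(=O)O` gives 3.68 h. Within the data shown here, the step between them, a 1.7-fold higher number from compound 1 to compound 2 (0.23 log units; within the scatter), leaves compound 2 within the scatter of compound 1, its only measured neighbour. Compound 3 `Cc1nc(-c2cc3cc(Oc4ccccc4)ccc3[nH]2)sc1C(=O)O` keeps the phenoxy group of compound 2 but has hydrogen in place of cyano on an aromatic carbon. Among the measured compounds shown here, the only measured step, a 1.7-fold higher number from compound 1 to compound 2 (0.23 log units; within the scatter), concerns phenyl in place of isopropyl on an oxygen, with the cyano unchanged. For the measured compounds named here, no measured pair shows what removing the cyano does. No step beyond the scatter is expected in this assay, in either direction. The expected change is a 1.2-fold lower number from compound 2 to compound 3 (0.06 log units; within the scatter). Compound 3 is estimated at 3.2 h, with an expected range from 1.5 h to 7 h.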

Compound 3, half-life: 1.94 h
Beside the measured number, compound 3's estimate is 1.6-fold (0.22 log units) above it; the measured number falls inside the stated range.
By their numbers in this assay, from the lowest: compounds 3, 1 and 2 (each within the scatter of the next).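

Among these compounds, until this result the cyano had stayed in place in every measured compound, so this aromatic carbon had no reading of its own. In this assay, hydrogen in place of cyano gives a 1.9-fold lower number from compound 2 to compound 3 (0.28 log units; within the scatter), so with the phenoxy group held constant, the loss of the cyano leaves the half-life inside the usual scatter. Nothing available speaks to the reason for this reading.

Among the compounds shown here, whether the same exchange would read alike with the isopropyl on the oxygen, as in compound 1, stays open: the only pair that covers this position carries the phenoxy group. Also open, from the compounds shown here alone, is what a chlorine atom, a methoxy group or an amine on this same aromatic carbon would give in this assay.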